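The source may hold more compounds than are shown below. What is called first, only, known or untested is meant among the compounds shown, and "the series" means these compounds.

Compound 1 `N#CCCN(Cc1cccs1)S(=O)(=O)c1ccc(F)cc1`: > 205000 nM
Compound 2 `N#CCCN(Cc1cccs1)S(=O)(=O)c1ccc([N+](=O)[O-])cc1`: > 189000 nM
Compound 3 `N#CCCN(Cc1cccs1)S(=O)(=O)c1ccc(N)cc1`: > 207000 nM

All three entries are limits of an ADME assay on MDCK cells (Canis lupus familiaris) for cytotoxicity, read by MTT assay, with a stated time of 24 h (on this read-out higher numbers stand for lower toxicity in this test and lower numbers for higher toxicity in this test), not numbers. Compound 1 therefore has no measured figure, only the limit of > 205000 nM in this assay, at which 1 of the 3 values shown sits.

The next compound, compound 4 `N#CCCN(Cc1ccccc1)S(=O)(=O)c1ccc(F)cc1`, keeps the rest of compound 1 and changes one group: phenyl in place of thiophen-2-yl on a saturated chain carbon bound to a sulfonamide nitrogen. Read one bond further out, the same change is (thiophen-2-yl)methyl to benzyl.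

For the measured compounds named here, no measured step touches that place. The three steps available all change the group on an aromatic carbon instead: a step that the two limits leave unreadable from compound 1 to compound 2, a step that the two limits leave unreadable from compound 1 to compound 3 and a step that the two limits leave unreadable from compound 2 to compound 3. None of them has a readable size, so there is no measured size to carry over to the new change. They show only that the fluoro, nitro and amino compounds all ended as limits.

With no evidence pointing either way, no step beyond the usual scatter is expected in this assay, in either direction. This expectation rests on compound 1, whose limit is > 205000 nM. The expected step is a step that the limit leaves unreadable from compound 1 to compound 4. Compound 4 may well end as a limit too. The estimate for compound 4 is 210000 nM, with an expected range from 100000 nM to 400000 nM.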

Compound 4, half-maximal cytotoxic concentration: > 209000 nM
Compound 4: no number, only a limit; the forecaster's own chance of this, stated with the estimate: 80%; the middle value lies beyond the limit too.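

Compound 1 and compound 4 both stand as limits, not numbers, and the step between them cannot be read. With all four compounds given only as limits, the compounds shown leave open whether phenyl in place of thiophen-2-yl, or any change on the aromatic carbon, alters the half-maximal cytotoxic concentration at all.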